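This account rests on a few compounds, and the source may have more. Where it says the series, first, only, none or still open, it means among the compounds named here.

Within the data shown here, in a functional assay for inhibition, with Homo sapiens as the target (a higher number here means a weaker inhibitor, a lower number a stronger inhibitor), compound 1 (`COc1ccc2nc(COc3ccc4c(c3)c(SC(C)(C)C)c(CC(C)(C)C(=O)O)n4Cc3ccc(Cl)cc3)sc2c1`) gives 8 nM and compound 2 (`C[C@@H](COc1ccc2c(c1)c(SC(C)(C)C)c(CC(C)(C)C(=O)O)n2Cc1ccc(Cl)cc1)c1ccccn1`) gives 2 nM as the lower of the two numbers so far. Compound 3 (`CC(C)(C)Sc1c(CC(C)(C)C(=O)O)n(Cc2ccc(Cl)cc2)c2ccc(OCc3cnccn3)cc12`) carries pyrazin-2-yl in place of 1-(pyridin-2-yl)ethyl on a saturated chain carbon bound to an oxygen on an aromatic ring. Among the measured compounds shown here, the one measured step at this place is a 4.0-fold lower number from compound 1 to compound 2 (0.60 log units; beyond the scatter) and it is modest but beyond the scatter. That step gives a size and no direction for the new group. In this assay a modest move to a higher number is expected, estimated as a 2.5-fold higher number from compound 2 to compound 3 (0.40 log units; beyond the scatter) overall. For compound 3 the expected value is 5 nM with an estimated range from 2 nM to 15 nM in this series.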

Compound 3, half-maximal inhibitory concentration: 4 nM
Compound 3: middle estimate off by 1.3-fold (0.10 log units), on the high side; the measured number falls inside the stated range.
By their numbers in this assay, from the lowest: compounds 2, 3 and 1 (each within the scatter of the next, the first and the last beyond it).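

On a saturated chain carbon bound to an oxygen on an aromatic ring, pyrazin-2-yl in place of 1-(pyridin-2-yl)ethyl in this assay gives a small step (a 2.0-fold higher number from compound 2 to compound 3 (0.30 log units; within the scatter)), and pyrazin-2-yl in place of 6-methoxy-1,3-benzothiazol-2-yl gives another (a 2.0-fold lower number from compound 1 to compound 3 (0.30 log units; within the scatter)). Compound 3, without the defined stereocentre of compound 2, thus stays within the scatter of both neighbours. No evidence bears on why these groups read so alike. Open, as far as these compounds go, is whether an amine or a carboxylic acid at this place stays in this range, and how the opposite enantiomer of compound 2 reads.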